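From ethoxy to isopropoxy at the assay limit

The source may hold more compounds than are shown below. What is called first, only, known or untested is meant among the compounds shown, and "the series" means these compounds.

Measured in a functional assay on PC-3 cells (Homo sapiens) for antiproliferative activity, with a stated time of 48 h; a higher number here means a weaker inhibitor, a lower number a stronger inhibitor:
Compound 1 `CCOC(=O)c1ccc(-c2ccc(N(C)C)nn2)cc1` gives > 25000 nM as a limit
Compound 2 `CCOC(=O)c1ccc(-c2ccc(OCC)nn2)cc1` gives > 25000 nM as a limit

In this assay compound 2 gives > 25000 nM as its result, and this is a limit and not a number. It is therefore known only as the limit of > 25000 nM in this assay, at which 2 of the 2 values shown sit, and has no exact place on the scale.

Among the compounds with values here, compound 3 `CCOC(=O)c1ccc(-c2ccc(OC(C)C)nn2)cc1` differs from compound 2 by methyl in place of hydrogen on a saturated chain carbon bound to an oxygen on an aromatic ring and a saturated chain carbon as its one change, turning ethoxy into isopropoxy. Within the data shown here, the only measured step is a step that the two limits leave unreadable from compound 1 to compound 2 and it gives no size to carry forward. Among the measured compounds shown here, it also concerns a different change, so no measured step bears directly on this one.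

No step beyond the usual scatter is expected, and no direction can be argued. The expectation rests on compound 2, whose > 25000 nM is a limit, so another limit is the likeliest report. The expected change is a step that the limit leaves unreadable from compound 2 to compound 3 in this estimate. Compound 3 is estimated at 30000 nM with an expected range from 12000 nM to 60000 nM as a rough guide.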

Compound 3, half-maximal inhibitory concentration: > 25000 nM
Compound 3 gave a limit, no number; the forecaster's own chance of this, stated with the estimate: 80%; the middle value lies beyond the limit too.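

In this assay compound 3 gives > 25000 nM as a limit and not a number. No step can be read among compound 1, compound 2 and compound 3, and the reason is their shared result: the limit of > 25000 nM in this assay, at which 3 of the 3 values shown sit.

These compounds leave open how far each lies from that limit, and which change to the shared core would give a measurable value.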